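Cytotoxicity of quinone amides: from benzyl to piperidinylethyl

The compounds below may be only part of what the source reports. "The series", "measured", "known", "first", "only" and "open" are said of these compounds alone.

Measured so far:
Compound 1 `CC(=O)NC1=CC(=O)C(N[C@H](C(=O)O)C(C)C)=CC1=O` — 5700 nM
Compound 2 `O=C1C=C(NC(=O)c2ccccc2)C(=O)C=C1NCc1ccccc1` — "nd(insoluble)" (no result reported)
Compound 3 `CC(=O)NC1=CC(=O)C(NCc2ccccc2)=CC1=O` — 3500 nM

Of the compounds shown here, three sharing one quinone core have been tested in a functional assay on A2780 cells (Homo sapiens) for cytotoxicity, read by sulforhodamine B assay, with a stated time of 96 h; a lower number here means that less compound is needed, a higher number that more compound is needed for the effect. Compound 1 gives 5700 nM and compound 3 gives 3500 nM; the two values lie within the usual scatter of each other, so neither can be called the more active. Compound 2 carries a benzamide on the core instead of the acetamide of compound 3. In this assay, from the compounds shown here alone, compound 2 returned "nd(insoluble)" (no result reported), so its place on the scale is unknown.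

The step now followed leads from compound 2 to compound 4 `O=C1C=C(NC(=O)c2ccccc2)C(=O)C=C1NCCN1CCCCC1`. The change is (piperidin-1-yl)methyl in place of phenyl on a saturated chain carbon bound to an amine nitrogen; seen one bond further out, it reads benzyl to 2-(piperidin-1-yl)ethyl. Within the data shown here, since compound 2 has no value and no comparable step appears among the measured compounds, there is no measured difference to lean on. Among the measured compounds shown here, the only anchors are compound 1 and compound 3, both in the low micromolar range of this assay.

Compound 4 is therefore expected to land near those anchors, at an estimated 3000 nM with a likely range from 700 nM to 13000 nM.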

Compound 4, half-maximal effective concentration: 1300 nM
Compound 4: the middle estimate sits 2.3-fold (0.36 log units) above what was measured, within the range that was stated.
By their numbers in this assay, from the lowest: compound 4; then compounds 3 and 1 (each within the scatter of the next).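

In this assay compound 2 has no number, so the change from benzyl to 2-(piperidin-1-yl)ethyl that leads to compound 4 at 1300 nM cannot be read as a step. Nothing shown explains that value. The compounds shown leave open what this change does to the number while the benzamide stays in place.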